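Aminophenyl to methoxyphenyl and back: an alkynyl series

The compounds below may be only part of what the source reports. "The series", "measured", "known", "first", "only" and "open" are said of these compounds alone.

Measured in a functional assay on A375-C5 cells (Homo sapiens) for inhibition, read by sulforhodamine B assay, with a stated time of 48 h; on this read-out higher numbers stand for weaker inhibition of growth and lower numbers for stronger inhibition of growth:
- compound 1 `COC(=O)c1sc2cc(C#Cc3ccc(N)cc3)cnc2c1N`: 4800 nM
- compound 2 `COC(=O)c1sc2cc(C#Cc3ccccc3OC)cnc2c1N`: a limit of the assay, > 47300 nM

Compound 2 sits only at a limit, > 47300 nM, the weaker end of the two numbers shown (the limit of > 47300 nM in this assay, at which 1 of the 2 values shown sits). Compound 3 `COC(=O)c1sc2cc(C#Cc3ccccc3N)cnc2c1N` differs from compound 2 by amino in place of methoxy on an aromatic carbon. Among the compounds with values here, the one measured step, an at least 9.8-fold higher number from compound 1 to compound 2 (0.99 log units; beyond the scatter), changes both the group and its place, so it bears on the present step only loosely. In this assay compound 3 is expected to move back toward compound 1 without reaching it, an estimated step of an at least 1.8-fold lower number from compound 2 to compound 3 (0.27 log units; that floor lies within the scatter), with the risk that only a limit is again reported. The estimate for compound 3 is 25000 nM, from 7000 nM to 90000 nM.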

Compound 3, concentration for 50% growth inhibition: 3100 nM
Compound 3: the middle estimate sits 8.1-fold (0.91 log units) above what was measured; the whole stated range lies above it.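

In this assay, 2-aminophenyl in place of 2-methoxyphenyl gives an at least 15-fold lower number from compound 2 to compound 3 (1.18 log units; beyond the scatter) and so separates the group from its place, which the earlier step could not do. Moving the amino group gives a 1.5-fold lower number from compound 1 to compound 3 (0.19 log units; within the scatter) and does not distinguish 2-aminophenyl from 4-aminophenyl. Compound 2 remains a limit of the assay, so the full size of its step stays unknown: the limit of > 47300 nM in this assay, at which 1 of the 3 values shown sits.

From the compounds shown here alone, whether a hydroxyl or a dimethylamino group at this place would behave like amino or like methoxy remains open. So does the effect of 4-methoxyphenyl on the shared core.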